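Moving the tetrahydronaphthalenyl attachment on the shared core

A few compounds are considered here, and "the series" means these few. Any claim that something is new, unique, unknown or untested is made for them only; others in the source may bear on it.

In a functional assay on HeLa cells (Homo sapiens) for cytotoxicity, read by MTT assay, with a stated time of 48 h (a lower number here means that less compound is needed, a higher number that more compound is needed for the effect), compound 1 (`CO[C@H]1O[C@H](COc2ccc(C3CCCCC3)cc2)[C@@H](O)[C@H](O)[C@H]1Oc1ccc(OC2CCCCC2)cc1`) gives 10000 nM. Compound 2 (`CO[C@H]1O[C@H](COc2ccc(C3CCCCC3)cc2)[C@@H](O)[C@H](O)[C@H]1Oc1cccc2c1CCCC2`) gives 25000 nM, the higher of the two numbers, and the gap between them lies beyond the scatter. Compound 3 (`CO[C@H]1O[C@H](COc2ccc(C3CCCCC3)cc2)[C@@H](O)[C@H](O)[C@H]1Oc1ccc2c(c1)CCCC2`) is not yet measured. It has the same atoms as compound 2, joined differently: 1,2,3,4-tetrahydronaphthalen-6-yl in place of 1,2,3,4-tetrahydronaphthalen-5-yl on an oxygen on a saturated carbon. Among the measured compounds shown here, no measured step covers this change, so the basis for prediction is thin. A small move to a lower number in this assay is expected, estimated as a 1.6-fold lower number from compound 2 to compound 3 (0.19 log units; within the scatter), which stays within the scatter. For compound 3 the expected value is 16000 nM, with an estimated range of 7000 nM to 35000 nM.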

Compound 3, half-maximal effective concentration: 29000 nM
Compound 3: middle estimate off by 1.8-fold (0.26 log units), on the low side; measured number inside the range.
By their numbers in this assay, from the lowest: compound 1; then compounds 2 and 3 (each within the scatter of the next).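

In this assay, 1,2,3,4-tetrahydronaphthalen-6-yl in place of 1,2,3,4-tetrahydronaphthalen-5-yl on this oxygen gives a 1.2-fold higher number from compound 2 to compound 3 (0.06 log units; within the scatter), so the point of attachment of this group makes no readable difference here. Among the compounds shown here, this is the only single change at this position with a step so far, and the same atoms joined differently hold their number within the scatter. No supporting data bear on this result.

From the compounds shown here alone, whether an amine or a carboxylic acid on the tetrahydronaphthalenyl group, or a longer chain in its place on this oxygen, would move the number beyond the scatter remains open.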